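From 3-Hydroxypiperidin-1-yl to Trifluoromethyl on the Shared Core

The source may report more compounds than this note shows. Statements on the series, on what has been measured and on what is new or still open speak of the compounds shown alone.

Measured compounds:
- compound 1, `Cc1cc(-c2ccccc2)c(S(C)(=O)=O)cc1C(=O)N=C(N)N`, 19 nM
- compound 2, `Cc1cc(N2CCCC(O)C2)c(S(C)(=O)=O)cc1C(=O)N=C(N)N`, 30 nM

Both compounds were tested in a functional assay for inhibition of sodium/hydrogen exchanger (Oryctolagus cuniculus); on this read-out lower numbers stand for stronger inhibition and higher numbers for weaker inhibition. Compound 2 shows the highest of the two numbers, and its nearest neighbour is compound 1, but the step of a 1.6-fold higher number from compound 1 to compound 2 (0.20 log units; within the scatter) lies within the scatter, so the two compounds cannot be told apart on these data.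

Compound 3, `Cc1cc(C(F)(F)F)c(S(C)(=O)=O)cc1C(=O)N=C(N)N`, has not been measured. It differs from compound 2 in one place: trifluoromethyl in place of 3-hydroxypiperidin-1-yl on an aromatic carbon. Among the measured compounds shown here, no measured step involves a trifluoromethyl group, so nothing speaks directly to this change. For the measured compounds named here, the only step on record, from compound 1 to compound 2, shows that exchanging the group at this position for a very different one left the number within the scatter. On that basis a step of a 1.2-fold lower number from compound 2 to compound 3 (0.08 log units; within the scatter) is expected, with no direction beyond the scatter, so compound 3 is estimated at 25 nM, in the range 8 nM to 80 nM.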

Compound 3, half-maximal inhibitory concentration: 37 nM
Compound 3: middle estimate off by 1.5-fold (0.17 log units), on the low side, and the stated range covers the measured number.
By their numbers in this assay, from the lowest: compounds 1, 2 and 3 (each within the scatter of the next).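

In this assay there is a 1.2-fold higher number from compound 2 to compound 3 (0.09 log units; within the scatter) for this change, and a 1.9-fold higher number from compound 1 to compound 3 (0.29 log units; within the scatter) when trifluoromethyl replaces phenyl on the same aromatic carbon. This position, ortho to a methylsulfonyl group, has now carried three quite different groups: phenyl, 3-hydroxypiperidin-1-yl, and trifluoromethyl, which has no ring and no hydrogen-bond donors or acceptors. Their numbers still cannot be told apart, and nothing available bears on why they sit so close together.

The compounds shown leave open whether a carboxylic acid, a primary amine or a longer alkyl chain at this position would also stay within the scatter of these three. They also leave open whether the same would hold on a core other than the shared one.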